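The compounds below may be only part of what the source reports. "The series", "measured", "known", "first", "only" and "open" are said of these compounds alone.

In a functional assay on MIA PaCa-2 cells (Homo sapiens) for antiproliferative activity, read by sulforhodamine B assay, with a stated time of 48 h (on this read-out lower numbers stand for stronger inhibition and higher numbers for weaker inhibition), three close relatives have been measured so far. Compound 1 (`COc1cc(OC)c2sc(-c3ccc(N/C=C\C(=O)c4ccc(OC)c([N+](=O)[O-])c4)cc3)nc2c1`) stands at 2900 nM and compound 2 (`COc1cc(OC)c2sc(-c3ccc(N/C=C\C(=O)c4ccc(OC)c(F)c4)c(C)c3)nc2c1`) at 16300 nM with compound 3 (`COc1ccc(C(=O)/C=C\Nc2ccc(-c3nc4cc(OC)c(OC)c(OC)c4s3)cc2)cc1F`) at 19400 nM on the same scale. Compound 3 thus lies within the usual scatter of compound 2 and is clearly weaker than compound 1. Compound 4 (`COc1cc(OC)c2sc(-c3ccc(N/C=C\C(=O)c4ccc(OC)c(F)c4)cc3)nc2c1`) alters one place of compound 3 (hydrogen in place of methoxy on an aromatic carbon) with hydrogen in place of methoxy on an aromatic carbon. Compound 1 at 2900 nM and compound 2 at 16300 nM also lack that methoxy, but they differ elsewhere too, so this evidence is loose. A modest step toward stronger inhibition is expected (a 2.4-fold lower number from compound 3 to compound 4 (0.38 log units; beyond the scatter)) here. Compound 4 is estimated at 8000 nM with a likely range from 2500 nM to 25000 nM overall.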

Compound 4, half-maximal inhibitory concentration: 4300 nM
For compound 4 the middle estimate is 1.9-fold (0.27 log units) above the measured one; low and high end bracket the measured number.
By their numbers in this assay, from the lowest: compounds 1 and 4 (each within the scatter of the next); then compounds 2 and 3 (each within the scatter of the next).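

In this assay, hydrogen in place of methoxy on the aromatic carbon ortho to two methoxy groups gives a 4.5-fold lower number from compound 3 to compound 4 (0.65 log units; beyond the scatter), so this extra methoxy group costs activity in a single-place comparison, and dropping a methyl group from the ring gives a 3.8-fold lower number from compound 2 to compound 4 (0.58 log units; beyond the scatter) in the same direction. Fluoro in place of nitro on an aromatic carbon gives a 1.5-fold higher number from compound 1 to compound 4 (0.17 log units; within the scatter), which shows no clear difference. Nothing measured here explains these steps. On these data alone, whether a hydroxy group or an amine on that first carbon would match hydrogen stays open, as does the effect of a chloro group in place of fluoro.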